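The source may hold more compounds than are shown below. What is called first, only, known or untested is meant among the compounds shown, and "the series" means these compounds.

Three compounds sharing one core were tested in a functional assay on HEL cells (Homo sapiens) for cytotoxicity, read by microscopy; a lower number here means that less compound is tolerated, a higher number that more compound is tolerated. Compound 1 `CCCCCc1cc2cn([C@H]3C[C@H](O)[C@@H](CO)O3)c(=O)nc2o1` gives > 50000 nM in this assay, which is a limit of the assay rather than a number. Compound 2 `C=CCCCc1cc2cn([C@H]3C[C@H](O)[C@@H](CO)O3)c(=O)nc2o1` likewise gives only a limit, > 200000 nM. Compound 3 `C=CCCCCc1cc2cn([C@H]3C[C@H](O)[C@@H](CO)O3)c(=O)nc2o1` also gives only a limit, > 200000 nM. Two of the three values sit at the limit of > 200000 nM in this assay, at which 2 of the 3 values shown sit, the other at the limit of > 50000 nM in this assay, at which 1 of the 3 values shown sits. Compound 4 `C=CCCCCCCc1cc2cn([C@H]3C[C@H](O)[C@@H](CO)O3)c(=O)nc2o1` differs from compound 3 by but-3-en-1-yl in place of vinyl on a saturated chain carbon, four bonds along the chain from an aromatic carbon. Within the data shown here, the steps that bear on this chain are a step that the two limits leave unreadable from compound 1 to compound 2, a step that the two limits leave unreadable from compound 1 to compound 3 and a step that the two limits leave unreadable from compound 2 to compound 3; none of them has a readable size, so no change beyond the scatter is expected in this assay. Compound 4 is therefore estimated at 200000 nM, between 100000 nM and 400000 nM. The expected step is a number no higher from compound 3 to compound 4 (the limit leaves the size open), with the result most likely again reported only as a limit.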

Compound 4, minimum cytotoxic concentration: > 200000 nM
Compound 4: only a limit was reported; the forecaster's own chance of this, stated with the estimate: 85%; the middle value sits exactly at the limit.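

In this assay compound 4, like compound 1, compound 2 and compound 3, gives only a limit, so no step among these compounds can be read. The compounds shown leave open at what concentration any of them becomes cytotoxic, and whether the chain changes that concentration.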